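The source may hold more compounds than are shown below. What is called first, only, known or untested is meant among the compounds shown, and "the series" means these compounds.

Measured in an ADME assay on A549 cells (Homo sapiens) for cytotoxicity, read by resazurin assay, with a stated time of 48 h; on this read-out lower numbers stand for higher toxicity in this test and higher numbers for lower toxicity in this test:
- compound 1 `CCCCCCC(C)Nc1ccc(NC(=O)c2cc(Cl)ccc2O)c(Cl)c1`: 23500 nM
- compound 2 `O=C(Nc1ccc(NCc2ccc(Cl)cc2)cc1Cl)c1cc(Cl)ccc1O`: 59700 nM
- compound 3 `O=C(Nc1ccc(NCc2cccc(C(F)(F)F)c2)cc1Cl)c1cc(Cl)ccc1O`: 13300 nM

The values of compound 3 and compound 1 lie within the usual scatter of each other, and both sit on the lower side of these numbers. Compound 2 stands apart from both.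

Compound 4 `COc1ccc(CNc2ccc(NC(=O)c3cc(Cl)ccc3O)c(Cl)c2)cc1` has not yet been measured. It differs from compound 3 in one place: 4-methoxyphenyl in place of 3-(trifluoromethyl)phenyl on a saturated chain carbon bound to a nitrogen on an aromatic ring. In words, 4-methoxyphenyl stands in place of 3-(trifluoromethyl)phenyl on a saturated chain carbon bound to a nitrogen on an aromatic ring.

For the measured compounds named here, two measured steps bear on this change. The closer one is a 4.5-fold lower number from compound 2 to compound 3 (0.65 log units; beyond the scatter), made at the same place, where 3-(trifluoromethyl)phenyl took the place of 4-chlorophenyl. The other is a 2.5-fold higher number from compound 1 to compound 2 (0.40 log units; beyond the scatter), where 4-chlorobenzyl took the place of 1-methylheptyl on a nitrogen on an aromatic ring. Both are modest. Going by the values given here, no measured compound carries 4-methoxyphenyl, so the direction is uncertain. With 3-(trifluoromethyl)phenyl gone, a partial return toward compound 2 at 59700 nM is expected, a modest move to a higher number.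

The expected step is a 2.4-fold higher number from compound 3 to compound 4 (0.38 log units; beyond the scatter). For compound 4 the estimated value is 32000 nM, with an expected range from 12000 nM to 85000 nM.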

Compound 4, half-maximal cytotoxic concentration: 80700 nM
Compound 4: middle estimate off by 2.5-fold (0.40 log units), on the low side, within the range that was stated.
By their numbers in this assay, from the lowest: compounds 3 and 1 (each within the scatter of the next); then compounds 2 and 4 (each within the scatter of the next).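

In this assay, the change at the saturated chain carbon bound to a nitrogen on an aromatic ring gives a 6.1-fold higher number from compound 3 to compound 4 (0.78 log units; beyond the scatter), so replacing 3-(trifluoromethyl)phenyl with 4-methoxyphenyl moves the number well beyond the scatter. The comparison with the 4-chlorophenyl compound gives a 1.4-fold higher number from compound 2 to compound 4 (0.13 log units; within the scatter), so methoxy and chloro cannot be told apart in this test, while a 3.4-fold higher number from compound 1 to compound 4 (0.54 log units; beyond the scatter) shows that 4-methoxybenzyl, like 4-chlorobenzyl, gives a higher number than 1-methylheptyl, a pattern that compound 3 does not share. Nothing available explains why these groups differ in this way.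

Compound 3 differs from compound 2 and compound 4 in both the substituent and the way it is named on the ring, so the compounds shown cannot separate the effect of trifluoromethyl itself from that of its placement. Going by these compounds, it also remains open where a plain phenyl, or a ring bearing an amine or a carboxylic acid, would fall in this assay at this same position.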